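Aryl swaps on the amide carbonyl of the shared core

This account rests on a few compounds, and the source may have more. Where it says the series, first, only, none or still open, it means among the compounds named here.

Compound 3 `O=C(Nc1ccc(Cl)c(-c2nnc3c(Cl)cccn23)c1)c1ccon1` carries a 1,2-oxazol-3-yl on the carbonyl carbon. In a functional assay on MDA-MB-468 cells (Homo sapiens) for antiproliferative activity, read by MTT assay, with a stated time of 72 h (a higher number here means a weaker inhibitor, a lower number a stronger inhibitor), compound 3 gives only a limit, > 100000 nM. Compound 1 `Cc1nc(C(=O)Nc2ccc(Cl)c(-c3nnc4c(Cl)cccn34)c2)cs1`, with a 2-methyl-1,3-thiazol-4-yl on that carbon, likewise gives only a limit in this assay, > 100000 nM. Compound 2 `Cc1cc(Cl)ccc1C(=O)Nc1ccc(Cl)c(-c2nnc3c(Cl)cccn23)c1`, with a 4-chloro-2-methylphenyl there, gives 34300 nM in this assay. Going from a substituted phenyl to the 1,2-oxazol-3-yl is read as an at least 2.9-fold higher number from compound 2 to compound 3 (0.46 log units; beyond the scatter), and an at least 2.9-fold lower number from compound 1 to compound 2 (0.46 log units; beyond the scatter) points the same way for the other heteroaryl. Compound 4 `O=C(Nc1ccc(Cl)c(-c2nnc3c(Cl)cccn23)c1)c1c(F)cccc1Cl` differs from compound 3 by 2-chloro-6-fluorophenyl in place of 1,2-oxazol-3-yl on a carbonyl carbon. A substituted phenyl returns, so a downward step beyond the scatter is expected, of the size an at least 3.3-fold lower number from compound 3 to compound 4 (0.52 log units; beyond the scatter). Compound 4 is estimated at 30000 nM, within 8000 nM to 100000 nM.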

Compound 4, half-maximal inhibitory concentration: 57600 nM
Estimate against measurement, compound 4: 1.9-fold (0.28 log units) below; measured number inside the range.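

A second substituted phenyl on the carbonyl carbon, 2-chloro-6-fluorophenyl, does not separate from the first, with a 1.7-fold higher number from compound 2 to compound 4 (0.23 log units; within the scatter) as the step. Unlike compound 2, compound 4 is not clearly set apart from the heteroaryl compounds, giving an at least 1.7-fold lower number from compound 3 to compound 4 (0.23 log units; that floor lies within the scatter) and an at least 1.7-fold lower number from compound 1 to compound 4 (0.23 log units; that floor lies within the scatter) as its steps. Both steps are only floors because each starts from a limit: the limit of > 100000 nM in this assay, at which 2 of the 4 values shown sit.

On these data alone, whether phenyl substitution matters at all remains open, as does the effect of an unsubstituted phenyl. As far as these compounds go, a phenyl bearing an amine or a carboxylic acid also remains untested in these notes.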